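Extending the side chain of compound 1: an expected outcome

The source may report more compounds than this note shows. Statements on the series, on what has been measured and on what is new or still open speak of the compounds shown alone.

Measured compounds:
compound 1 `COc1cccc(NC(=O)Oc2cc(=O)n(CCCO)c3c2CC(CC=C(C)C)C(C)(C)C3)c1` — 16.2%
compound 2 `CC(C)=CCC1Cc2c(OC(=O)Nc3ccccc3F)cc(=O)n(CCCO)c2CC1(C)C` — 52.3%

Of the compounds shown here, two sharing one core have been measured in a functional assay on PANC-1 cells (Homo sapiens) for inhibition, read by MTT assay, with a stated time of 24 h, tested at 10 uM; on this read-out lower numbers stand for less inhibition and higher numbers for more inhibition at the one concentration tested (going by the name of the read-out). Compound 1 gives 16.2%, the lowest of the two numbers. Its nearest neighbour is compound 2, which gives 52.3%; the step of a number 36.1 percentage points higher from compound 1 to compound 2 (beyond the scatter) lies beyond the scatter and comes from a 2-fluorophenyl in place of 3-methoxyphenyl on an amide-type nitrogen.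

Compound 3 `COc1cccc(NC(=O)Oc2cc(=O)n(CCCO)c3c2CC(C/C=C(\C)CCC=C(C)C)C(C)(C)C3)c1` has not yet been measured. It differs from compound 1 by 3-methylbut-2-en-1-yl in place of hydrogen on a saturated chain carbon bound to a double-bonded chain carbon. Among the compounds with values here, this change is far from the aryl group that was varied between compound 1 and compound 2, so the one measured step does not bear on it directly; the data hold no step at this chain. Compound 1 is therefore the only anchor, and the expectation is that the step of a number 5.8 percentage points higher from compound 1 to compound 3 (within the scatter) stays small, without a clear direction beyond the scatter. Compound 3 is estimated to give 22% in this assay, within a range from 5% to 45%.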

Compound 3, a percentage reported as inhibition, at one concentration (the size of the read-out at that concentration, not a potency): 47%
The estimate for compound 3 lay 25 percentage points below the measured number; measured number above the stated range.
By their numbers in this assay, from the lowest: compound 1; then compounds 3 and 2 (each within the scatter of the next).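

With the 3-methoxyphenyl group left unchanged, placing 3-methylbut-2-en-1-yl on a saturated chain carbon bound to a double-bonded chain carbon gives a number 30.8 percentage points higher from compound 1 to compound 3 (beyond the scatter) in this assay. The earlier compounds shown here showed a change only at the aryl group, through a number 36.1 percentage points higher from compound 1 to compound 2 (beyond the scatter), whereas this result shows that going from 3-methylbut-2-en-1-yl to 3,7-dimethylocta-2,6-dien-1-yl at the far end of the chain also moves the number beyond the scatter, so two separate places on the shared core now matter. Nothing available bears on why the chain has this effect.

From the compounds shown here alone, it remains open whether the rise continues with a still longer chain, such as 3,7,11-trimethyldodeca-2,6,10-trien-1-yl, or depends on the double bonds, which a saturated chain such as 3,7-dimethyloctyl would test, and whether a chain ending in an amine or a carboxylic acid would keep it. Going by these compounds, it is also open whether the 2-fluorophenyl group and the 3,7-dimethylocta-2,6-dien-1-yl chain would add up when carried together on the shared core.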